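Dichlorophenyl to Ethoxyphenyl on the Ring Amine

The source may hold more compounds than are shown below. What is called first, only, known or untested is meant among the compounds shown, and "the series" means these compounds.

Going by the values given here, compound 1 `Cc1nc(-c2ccccc2)c(C(=O)N2CCN(c3cccc(Cl)c3Cl)CC2)o1` is the only compound here with a single number in a functional assay on HL-60 cells (Homo sapiens) for inhibition, read by MTT assay, with a stated time of 72 h; on this read-out higher numbers stand for weaker inhibition and lower numbers for stronger inhibition: compound 1 gives 133 nM. Compound 2 `Cc1nc(-c2cccc(OP(=O)(O)O)c2)c(C(=O)N2CCN(c3cccc(Cl)c3)CC2)o1` reaches only a limit of the assay, > 1000 nM, which is the limit of > 1000 nM in this assay, at which 1 of the 3 values shown sits. Compound 3 `O=C(c1oc(C2CCCCC2)nc1-c1ccccc1F)N1CCN(c2cccc(Cl)c2)CC1` is recorded in this assay as "not active" (no number reported), without any number. Among the compounds with values here, no pair of measured compounds differs in one place, so no measured step is available. Compound 4 `CCOc1cccc(N2CCN(C(=O)c3oc(C)nc3-c3ccccc3)CC2)c1` differs from compound 1 by 3-ethoxyphenyl in place of 2,3-dichlorophenyl on an amine nitrogen in a ring: the 2,3-dichlorophenyl with its 2 chlorine atoms leaves, and a 3-ethoxyphenyl with 1 hydrogen-bond acceptor enters. Compound 4 is expected to be weaker, and the step of a 4.5-fold higher number from compound 1 to compound 4 (0.65 log units; beyond the scatter) is estimated to lie beyond the usual scatter. Compound 4 is estimated at 600 nM, between 150 nM and 3000 nM.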

Compound 4, half-maximal inhibitory concentration: 151 nM
Estimate against measurement, compound 4: 4.0-fold (0.60 log units) above, and the stated range covers the measured number.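

In this assay, the first pair differing in one place gives a 1.1-fold higher number from compound 1 to compound 4 (0.06 log units; within the scatter), so 3-ethoxyphenyl and 2,3-dichlorophenyl on an amine nitrogen in a ring cannot be told apart. With the rest of the core of compound 1 unchanged, the two chlorine atoms are therefore not needed for a number at this level. Nothing shown here accounts for this match.

On these data alone, it remains open whether an unsubstituted phenyl or a pyridine on that nitrogen would hold this level. As far as these compounds go, it is equally open how a longer chain, such as butoxy, would compare with ethoxy.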